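Moving an amino group around a phenyl ring

The compounds below may be only part of what the source reports. "The series", "measured", "known", "first", "only" and "open" are said of these compounds alone.

Within the data shown here, the two compounds measured so far share one core and differ only in the aryl group carried on the nitrogen. Compound 1 has the structure `Fc1cccc(-c2nc(Nc3cccc(Cl)c3)c3cc(F)ccc3n2)c1` and compound 2 the structure `Nc1ccc(Nc2nc(-c3cccc(F)c3)nc3ccc(F)cc23)cc1`. In a functional assay on HL-60 cells (Homo sapiens) for cytotoxicity, read by MTT assay, with a stated time of 48 h (a lower number here means a stronger inhibitor, a higher number a weaker inhibitor), compound 1 gives only a limit of the assay, > 50000 nM. In this assay compound 2 likewise gives only a limit, > 50000 nM. The change that leads from compound 1 to compound 2 is a step that the two limits leave unreadable from compound 1 to compound 2, so its size cannot be read. This leaves compound 2 standing at the limit of > 50000 nM in this assay, at which 2 of the 2 values shown sit, with no number attached to it.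

Compound 3, with the structure `Nc1ccccc1Nc1nc(-c2cccc(F)c2)nc2ccc(F)cc12`, is the next compound to be measured. It differs from compound 2 by 2-aminophenyl in place of 4-aminophenyl on a nitrogen on an aromatic ring. Among the measured compounds shown here, no measured step speaks to this change, and the single step known, from compound 1 to compound 2, is unreadable. Compound 3 is therefore expected to stay close to where compound 2 stands, with an expected step that the limit leaves unreadable from compound 2 to compound 3. For compound 3 the estimate in this assay is 60000 nM, within a range from 15000 nM to 200000 nM.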

Compound 3, half-maximal inhibitory concentration: 41300 nM
Compound 3: middle estimate off by 1.5-fold (0.16 log units), on the high side; the measured number falls inside the stated range.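

Among these compounds, with compound 3, a group on this nitrogen gives a measured number in this assay for the first time, rather than a limit of the assay, and it does so with the same atoms as compound 2, joined differently. Moving the amino group to give 2-aminophenyl in place of 4-aminophenyl is an at least 1.2-fold lower number from compound 2 to compound 3 (0.08 log units; that floor lies within the scatter), and replacing 3-chlorophenyl with 2-aminophenyl is an at least 1.2-fold lower number from compound 1 to compound 3 (0.08 log units; that floor lies within the scatter). Neither step shows a real gain, since each is only a floor that lies within the scatter, and its true size stays unknown because compound 1 and compound 2 both rest on a limit: the limit of > 50000 nM in this assay, at which 2 of the 3 values shown sit.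

The compounds shown cannot say whether the amine itself matters in 2-aminophenyl, or whether any group at that place would read the same; 2-hydroxyphenyl or 2-methoxyphenyl on the same nitrogen would test this directly. On these data alone, they also leave the rest of the molecule untouched, so it remains open how a plain phenyl in place of the 3-fluorophenyl on the shared core would behave alongside 2-aminophenyl.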